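Benzofuran in place of hydroxy-methoxyphenyl: working notes

The compounds below may be only part of what the source reports. "The series", "measured", "known", "first", "only" and "open" are said of these compounds alone.

For the measured compounds named here, compound 2 `COc1cc(O)cc(CN[C@@H]2CO[C@H](C(c3ccccc3)c3ccccc3)C[C@H]2O)c1` gives 44.2 nM in an assay on Cerebral cortex for inhibition of Norepinephrine transporter (Rattus norvegicus) (on this read-out higher numbers stand for weaker inhibition and lower numbers for stronger inhibition), the highest of the two numbers so far. Its nearest neighbour is compound 1 `COc1cc(CN[C@@H]2CO[C@H](C(c3ccccc3)c3ccccc3)C[C@H]2O)ccc1O`, which in this assay gives 33.7 nM. Going by the values given here, the one measured step, a 1.3-fold higher number from compound 1 to compound 2 (0.12 log units; within the scatter), moves the hydroxy and methoxy groups around the ring on a saturated chain carbon bound to an amine nitrogen and leaves the number essentially where it was.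

Compound 3 `O[C@@H]1C[C@@H](C(c2ccccc2)c2ccccc2)OC[C@H]1NCc1ccc2occc2c1` is not yet measured. It differs from compound 2 as follows: 1-benzofuran-5-yl in place of 3-hydroxy-5-methoxyphenyl on a saturated chain carbon bound to an amine nitrogen. The measured step bears only loosely on this change: it shifted substituents on the same ring, whereas here the ring itself is exchanged and the hydrogen-bond donor is lost, and that step was within the scatter. Nothing measured shows what removing the donor or fusing on a five-membered aromatic ring does in this assay. The step of a 1.3-fold lower number from compound 2 to compound 3 (0.10 log units; within the scatter) is therefore expected to be small, with no confident direction and no strong reason to expect a move beyond the scatter. Compound 3 is estimated at 35 nM in this assay, in the range 10 nM to 120 nM.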

Compound 3, inhibition constant: 33.6 nM
Compound 3: the middle estimate sits 1.0-fold (0.02 log units) above what was measured, within the range that was stated.
By their numbers in this assay, from the lowest: compounds 3, 1 and 2 (each within the scatter of the next).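

Replacing the substituted phenyl on a saturated chain carbon bound to an amine nitrogen with 1-benzofuran-5-yl gives a 1.3-fold lower number from compound 2 to compound 3 (0.12 log units; within the scatter) and a 1.0-fold lower number from compound 1 to compound 3 (0.00 log units; within the scatter) in this assay, so both steps stay within the scatter. The earlier pair only moved the hydroxy and methoxy groups around one ring, whereas this result shows the position tolerating a different ring system of the same heavy-atom count: 3-hydroxy-5-methoxyphenyl carries 1 hydrogen-bond donor and 1-benzofuran-5-yl carries 0 hydrogen-bond donors, with the numbers of all three compounds within the scatter of one another. No supporting data on why the number holds are available here.

The compounds shown leave open whether this tolerance extends to groups without a ring oxygen, such as an unsubstituted phenyl or a pyridine ring, or to a longer chain on the amine nitrogen. The shared core is the same in all three compounds, so they give no reading on how the number in this assay responds to a change anywhere else in the structure.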